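From Methoxyphenyl to Trifluoromethylphenyl on a Shared Core

The source may report more compounds than this note shows. Statements on the series, on what has been measured and on what is new or still open speak of the compounds shown alone.

Of the compounds shown here, three sharing one core have been measured in a functional assay on RPMI-8226 cells (Homo sapiens) for inhibition, read by sulforhodamine B assay, with a stated time of 48 h, tested at 10 uM; on this read-out lower numbers stand for less inhibition and higher numbers for more inhibition at the one concentration tested (going by the name of the read-out). Compound 1 `CC(=O)c1ccc(-c2cn3ccnc3c(-c3ccc4ncn(C5CCCCC5)c4c3)n2)cc1` carries a 4-acetylphenyl group and gives 20.8%; compound 2 `Clc1ccc(-c2cn3ccnc3c(-c3ccc4ncn(C5CCCCC5)c4c3)n2)cc1`, with a 4-chlorophenyl group, gives 19%; compound 3 `COc1ccccc1-c1cn2ccnc2c(-c2ccc3ncn(C4CCCCC4)c3c2)n1`, with a 2-methoxyphenyl group, gives 35.9%. Compound 3 stands highest of the three: the step of a number 15.1 percentage points higher from compound 1 to compound 3 (beyond the scatter) and the step of a number 16.9 percentage points higher from compound 2 to compound 3 (beyond the scatter) both lie beyond the scatter, whereas the step of a number 1.8 percentage points lower from compound 1 to compound 2 (within the scatter) does not.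

Compound 4 `FC(F)(F)c1cccc(-c2cn3ccnc3c(-c3ccc4ncn(C5CCCCC5)c4c3)n2)c1` has not yet been measured. Its change from compound 3 is 3-(trifluoromethyl)phenyl in place of 2-methoxyphenyl on an aromatic carbon. Among the compounds with values here, no measured step swaps one aryl group for another in just this way; the nearest guide is that both compounds carrying an aryl group other than 2-methoxyphenyl, compound 1 and compound 2, sit below compound 3 by modest steps. On that basis a modest fall is expected, and the step of a number 11.9 percentage points lower from compound 3 to compound 4 (beyond the scatter) is the estimated outcome. Compound 4 is therefore expected to give 24%, within a range from 8% to 40%.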

Compound 4, a percentage reported as inhibition, at one concentration (the size of the read-out at that concentration, not a potency): 32.1%
Beside the measured number, compound 4's estimate is 8.1 percentage points below it; the range from low to high includes it.
By their numbers in this assay, from the lowest: compounds 2 and 1 (each within the scatter of the next); then compounds 4 and 3 (each within the scatter of the next).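

In this assay the step to the 3-(trifluoromethyl)phenyl group, a number 3.8 percentage points lower from compound 3 to compound 4 (within the scatter), shows that the 2-methoxyphenyl group is not alone in reaching this level at this position. The entering group counts no hydrogen-bond acceptor, so the acceptor of the 2-methoxyphenyl group is not needed for that level. With a number 13.1 percentage points higher from compound 2 to compound 4 (beyond the scatter) and a number 11.3 percentage points higher from compound 1 to compound 4 (beyond the scatter), the shared core now splits into two pairs, compounds 3 and 4 standing apart from compounds 1 and 2.

The compounds shown leave open whether the place of the substituent on the phenyl ring or its identity separates these pairs, and how an amine or a carboxylic acid on that ring would read. No measurement shown here explains why these groups give these numbers.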